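Where the Fluorine Sits: Three Measured Compounds, One Estimate

The source may report more compounds than this note shows. Statements on the series, on what has been measured and on what is new or still open speak of the compounds shown alone.

Compound 1, `Oc1ccccc1-c1cc(-c2cccc(F)c2)cc(-c2ccccc2O)n1`: in a functional assay on DU-145 cells (Homo sapiens) for inhibition (on this read-out lower numbers stand for stronger inhibition and higher numbers for weaker inhibition), compound 1 gives > 50000 nM, which is a limit of the assay and not a number.
Compound 2, `Oc1ccccc1-c1cc(-c2ccc(F)cc2)cc(-c2ccccc2O)n1`: in this assay compound 2 gives > 50000 nM, again a limit of the assay rather than a number.
Among the measured compounds shown here, compound 3, `Oc1cccc(-c2cc(-c3cccc(F)c3)cc(-c3cccc(O)c3)n2)c1`: in this assay compound 3 gives 23800 nM, the only number among the three.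

Compound 1 and compound 2 differ by 4-fluorophenyl in place of 3-fluorophenyl on an aromatic carbon. The step this makes is a step that the two limits leave unreadable from compound 1 to compound 2, and its size cannot be read because of the limit of > 50000 nM in this assay, at which 2 of the 3 values shown sit. For the measured compounds named here, compound 3 carries a different core from compound 1; how the two cores differ is not broken down here, and the two values show only that compound 3 gives a number where compound 1 gives a limit.

Compound 4, `Oc1cccc(-c2cc(-c3ccc(F)cc3)cc(-c3cccc(O)c3)n2)c1`, is not yet measured. It differs from compound 3 by 4-fluorophenyl in place of 3-fluorophenyl on an aromatic carbon. Going by the values given here, this is the same kind of change as the one from compound 1 to compound 2, but not the same: there the place was meta to two 2-hydroxyphenyl groups, here it is meta to two 3-hydroxyphenyl groups. Among the compounds with values here, the only measured instance of this kind of change is unreadable, so the expectation rests on compound 3 alone, whose value in this assay is 23800 nM. The step expected from compound 3 to compound 4 in this assay is estimated as a 1.3-fold higher number from compound 3 to compound 4 (0.10 log units; within the scatter), which is within the usual scatter. Compound 4 is therefore estimated at 30000 nM in this assay, with the likely range running from 10000 nM to 80000 nM.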

Compound 4, half-maximal inhibitory concentration: 7120 nM
For compound 4 the middle estimate is 4.2-fold (0.62 log units) above the measured one, and the stated range ends above it.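

On the core with two 3-hydroxyphenyl groups, 4-fluorophenyl in place of 3-fluorophenyl gives, in this assay, a 3.3-fold lower number from compound 3 to compound 4 (0.52 log units; beyond the scatter), a step that stands clear of the usual scatter. The same change on the core with two 2-hydroxyphenyl groups cannot be read, because compound 1 and compound 2 both rest at a limit of the assay and neither gives a number: the limit of > 50000 nM in this assay, at which 2 of the 4 values shown sit. The account therefore holds one readable instance of this change, which shows that moving the fluorine can shift the read-out on one core, but it does not show that the change carries from one core to the other, and a step of like size, of another size or of none on the core of compound 1 all remain possible.

What the compounds shown leave open is whether the step would hold on a core bearing two 4-hydroxyphenyl groups, or with an amine or a methoxy group where the hydroxyl groups stand. Also open, on these data alone, is how a 2-fluorophenyl or a 4-chlorophenyl group would read in that same place, opposite the ring nitrogen, on the core shared by compound 3 and compound 4.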